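A few compounds are considered here, and "the series" means these few. Any claim that something is new, unique, unknown or untested is made for them only; others in the source may bear on it.

Within the data shown here, in a functional assay on the whole organism with Mus musculus as the target, in the writhing test (a higher number here means that more compound is needed for the effect, a lower number that less compound is needed), only two compounds have numbers so far. Compound 1 `CCCCSc1nsnc1C1CN2CCCC1C2` gives 0.03 mg/kg, and compound 2 `FC(F)(F)CCCSc1nsnc1C1CN2CCCC1C2` gives 0.1 mg/kg, the higher of the two, so more of compound 2 is needed for the effect. Compound 3 `CC(C)CCCSc1nsnc1C1CN2CCCC1C2` has isopropyl in place of trifluoromethyl on a saturated chain carbon, three bonds along the chain from a sulfur. Among the measured compounds shown here, one measured step bears on this change, and it is modest: a 3.3-fold higher number from compound 1 to compound 2 (0.52 log units; beyond the scatter), with trifluoromethyl replacing methyl at that same place. Compound 3 also loses the trifluoromethyl, so part of that step is expected to reverse. For the measured compounds named here, its isopropyl is not the methyl of compound 1, however, and no measured compound carries isopropyl. A modest move to a lower number is therefore expected, and the estimated step is a 2.5-fold lower number from compound 2 to compound 3 (0.40 log units; beyond the scatter). The expected value for compound 3 is 0.04 mg/kg, with an estimated range of 0.012 mg/kg to 0.15 mg/kg.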

Compound 3, dose for half-maximal effect: 0.95 mg/kg
The estimate for compound 3 lay 24-fold (1.38 log units) below the measured number; the measured number lies above the stated range.
By their numbers in this assay, from the lowest: compound 1; then compound 2; then compound 3.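

In this assay, the group at the end of this chain matters more than the first pair suggested: isopropyl in place of trifluoromethyl gives a 9.5-fold higher number from compound 2 to compound 3 (0.98 log units; beyond the scatter) and does not return the number towards that of compound 1. Measured against methyl at the same place, isopropyl gives a 32-fold higher number from compound 1 to compound 3 (1.50 log units; beyond the scatter) and is a much larger penalty than trifluoromethyl, which gives a 3.3-fold higher number from compound 1 to compound 2 (0.52 log units; beyond the scatter) and is the smaller of these two changes, even though isopropyl has 3 heavy atoms and trifluoromethyl has 4. No measurement here explains this difference between the two groups.

The compounds shown leave open whether an ethyl group at this place would stay near compound 1 or move towards compound 3. They also leave open how a hydroxyl group or a longer chain would behave there.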